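Same atoms, joined differently: expecting compound 4

The source may hold more compounds than are shown below. What is called first, only, known or untested is meant among the compounds shown, and "the series" means these compounds.

compound 1 `O=C(NCc1ccc(S(=O)(=O)c2ccccc2)cc1)c1cc2ccncc2s1` gives 21%
compound 2 `O=C(NCc1ccc(S(=O)(=O)c2ccccc2)cc1)c1cc2ncccc2s1` gives 1.6%
compound 3 `O=C(NCc1ccc(S(=O)(=O)c2ccccc2)cc1)c1cn2ccnc2cn1` gives 13%

These numbers come from an ADME assay on microsomes from liver (Mus musculus) for metabolic stability, read by LC-MS, with a stated time of 30 min, tested at 1 uM (on this read-out higher numbers stand for a more stable compound and lower numbers for a less stable compound), and the three compounds differ only in the group on the carbonyl carbon. Compound 3, at 13%, cannot be told apart from compound 1, as the data show a number 8 percentage points lower from compound 1 to compound 3 (within the scatter). It stands clear of compound 2, with a number 11.4 percentage points higher from compound 2 to compound 3 (beyond the scatter).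

Compound 4 `O=C(NCc1ccc(S(=O)(=O)c2ccccc2)cc1)c1ccc2nncn2c1` has the same atoms as compound 3, joined differently: a group of 9 heavy atoms (6 carbon, 3 nitrogen; one five-membered aromatic ring with 3 hetero atoms, one six-membered aromatic ring with 1 hetero atom) in place of a group of 9 heavy atoms (6 carbon, 3 nitrogen; one five-membered aromatic ring with 2 hetero atoms, one six-membered aromatic ring with 2 hetero atoms), on a carbonyl carbon.

All three measured steps are swaps of one such group for another of equal size, and they do not agree in size. The largest is a number 19.4 percentage points lower from compound 1 to compound 2 (beyond the scatter), so a swap of this kind can matter, yet three compounds point in no direction for this new group. No step beyond the scatter is therefore expected, though a larger one remains possible. The expected step is a number 1 percentage points lower from compound 3 to compound 4 (within the scatter). For compound 4 the estimate is 12%, with an expected range from 3% to 28%.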

Compound 4, percent of the compound remaining: 47%
The estimate for compound 4 lay 35 percentage points below the measured number, and the stated range ends below it.
By their numbers in this assay, from the lowest: compound 2; then compounds 3 and 1 (each within the scatter of the next); then compound 4.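

In this assay, going by these compounds alone, the group on the carbonyl carbon matters more than the earlier compounds could show: a number 34 percentage points higher from compound 3 to compound 4 (beyond the scatter) comes from joining the same atoms differently, while the counts of hydrogen-bond donors and acceptors and the net charge stay the same. The new group, with three hetero atoms in its five-membered ring and one in its six-membered ring, also stands clear of both sulfur-containing groups, with a number 45.4 percentage points higher from compound 2 to compound 4 (beyond the scatter) and a number 26 percentage points higher from compound 1 to compound 4 (beyond the scatter) making compound 4 the most stable of the four. Nothing measured here explains why this arrangement gives the higher number.

On these data alone, it remains open whether the number holds when a methyl group or a chlorine atom is added to the new group. Whether a plain phenyl ring on the carbonyl carbon would fall nearer compound 4 or compound 2 is also unknown.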